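This account rests on a few compounds, and the source may have more. Where it says the series, first, only, none or still open, it means among the compounds named here.

Of the compounds shown here, two built on the same core have been tested in an assay on lysate for inhibition of 6-phosphofructo-2-kinase/fructose-2,6-bisphosphatase 3 (Homo sapiens), with stated times of 0.5 min and 45 min; on this read-out higher numbers stand for weaker inhibition and lower numbers for stronger inhibition. Compound 1 `Cn1cc(CNC(=O)c2ccncc2Nc2cc(-c3ccc4ccn(C)c4c3)c3nccnc3c2)cn1` carries a 1-methyl-1H-pyrazol-4-yl group on a saturated chain carbon bound to an amide-type nitrogen, and in this assay compound 1 gives 75900 nM. Compound 2 `CC(=O)N1CCOC(CNC(=O)c2ccncc2Nc2cc(-c3ccc4ccn(C)c4c3)c3nccnc3c2)C1` has 4-acetylmorpholin-2-yl in that place. For compound 2 this assay reports only a limit, > 100000 nM; this is the limit of > 100000 nM in this assay, at which 1 of the 2 values shown sits, not a number. Within the data shown here, the single measured step, an at least 1.3-fold higher number from compound 1 to compound 2 (0.11 log units; that floor lies within the scatter), therefore only says that compound 2 is no stronger than compound 1, and its floor sits within the usual scatter.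

Compound 3 `CN1CC(NC(=O)c2ccncc2Nc2cc(-c3ccc4ccn(C)c4c3)c3nccnc3c2)C1` has not yet been measured. The change from compound 2 to compound 3 is 1-methylazetidin-3-yl in place of (4-acetylmorpholin-2-yl)methyl on an amide-type nitrogen. Among the measured compounds shown here, no measured step touches the amide-type nitrogen itself in this way, so the only bearing comes from the fact that both compounds 1 and 2 sit at the weak end of this assay. On that ground compound 3 is expected near the same level, with an estimated step of a number no higher from compound 2 to compound 3 (the limit leaves the size open). The expected value for compound 3 is 100000 nM, within 30000 nM to 300000 nM.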

Compound 3, half-maximal inhibitory concentration: 9190 nM
For compound 3 the middle estimate is 11-fold (1.04 log units) above the measured one, outside the stated range (below it).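

Compound 3 shows that the group on the amide-type nitrogen can move the result in this assay, which compounds 1 and 2 could not show, as both sat at the weak end. Measured against a full value, the change to 1-methylazetidin-3-yl gives an 8.3-fold lower number from compound 1 to compound 3 (0.92 log units; beyond the scatter), and against the morpholine-bearing compound it gives an at least 10-fold lower number from compound 2 to compound 3 (1.03 log units; beyond the scatter), so compound 3 is the strongest of the three shown. The second of these steps has a floor but no known full size, as compound 2 is recorded only as a limit, not a number: the limit of > 100000 nM in this assay, at which 1 of the 3 values shown sits.

Each step to compound 3 changes several features at once, replacing the ring, dropping the carbon that links the ring to the amide-type nitrogen in compounds 1 and 2, and, in the step from compound 1, exchanging an aromatic ring for a saturated one, so the compounds shown do not say which of these matters. A (1-methylazetidin-3-yl)methyl group would separate the ring from the link, and an azetidin-3-yl group lacking the methyl on nitrogen or a 1-methylpiperidin-4-yl group would test whether the gain depends on that methyl or on the size of the ring.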